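A few compounds are considered here, and "the series" means these few. Any claim that something is new, unique, unknown or untested is made for them only; others in the source may bear on it.

Measured compounds and their values:
compound 1 `CCC1CCCN(C(=O)CN2CN(c3ccccc3)C3(CCN(C(=O)c4ccc(C5CCCCC5)cc4)CC3)C2=O)C1` gives 2600 nM
compound 2 `CC1(C)CC(OC(=O)CN2CN(c3ccccc3)C3(CCN(C(=O)c4ccc(C5CCCCC5)cc4)CC3)C2=O)CC(C)(C)N1` gives 600 nM
compound 3 `CC(C)(C)c1ccc(C(=O)N2CCC3(CC2)C(=O)N(CC(=O)N2CCCC(O)C2)CN3c2ccccc2)cc1` gives 12200 nM

These three share a core and were tested in an assay on HEK293 cells for displacement of a labelled ligand from NPC1-like intracellular cholesterol transporter 1 (Homo sapiens); on this read-out lower numbers stand for stronger inhibition and higher numbers for weaker inhibition. Among them compound 3 stands at the highest number, so it is the weakest binder of the set; its nearest neighbour is compound 1 and its furthest compound 2. Among the compounds with values here, the only single-point step known is a 4.3-fold lower number from compound 1 to compound 2 (0.64 log units; beyond the scatter), which swaps the whole group on the carbonyl carbon rather than a substituent on a ring carbon.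

Compound 4 `CCOC(=O)C1CCCN(C(=O)CN2CN(c3ccccc3)C3(CCN(C(=O)c4ccc(C(C)(C)C)cc4)CC3)C2=O)C1` is not yet measured. It differs from compound 3 by ethoxycarbonyl in place of hydroxy on a saturated ring carbon. Within the data shown here, no measured step changes the same kind of position, so the step from compound 1 to compound 3 can only be read as two values, not as a single change. With nothing directly comparable, only a modest gain is expected for compound 4, around a 2.0-fold lower number from compound 3 to compound 4 (0.31 log units; beyond the scatter), with wide uncertainty. Compound 4 is therefore estimated at 6000 nM, between 2000 nM and 20000 nM.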

Compound 4, half-maximal inhibitory concentration: 8200 nM
Beside the measured number, compound 4's estimate is 1.4-fold (0.14 log units) below it, and the stated range covers the measured number.
By their numbers in this assay, from the lowest: compound 2; then compound 1; then compounds 4 and 3 (each within the scatter of the next).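

In this assay, the swap of hydroxy for ethoxycarbonyl gives a 1.5-fold lower number from compound 3 to compound 4 (0.17 log units; within the scatter), so the two compounds cannot be told apart. Within the data shown here, this is the first view of this position, on a saturated ring carbon two ring bonds from the ring nitrogen, and it shows that a large change in the group need not register: five heavy atoms enter where one leaves, and the hydrogen-bond donor of hydroxy is gone, yet the read-out stays within its usual scatter. Nothing on hand explains this result.

The compounds shown leave open how a carboxylic acid or an amine on this same ring carbon would read in this assay. Also open, from the compounds shown here alone, is whether hydroxy and ethoxycarbonyl would still read alike with other groups elsewhere on the shared core.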